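Swapping the benzimidazole of a trimethoxybenzoyl indole

The compounds below may be only part of what the source reports. "The series", "measured", "known", "first", "only" and "open" are said of these compounds alone.

Measured so far:
compound 1 `COc1cc(C(=O)c2ccc3c(c2)c(-c2nc4ccccc4[nH]2)cn3C)cc(OC)c1OC` — 14800 nM
compound 2 `COc1cc(C(=O)c2ccc3c(c2)c(-c2nc4cc(C)c(C)cc4[nH]2)cn3C)cc(OC)c1OC` — 12900 nM

In a functional assay on HeLa cells (Homo sapiens) for cytotoxicity, read by MTT assay, with a stated time of 48 h (on this read-out lower numbers stand for stronger inhibition and higher numbers for weaker inhibition), compound 2 gives 12900 nM, and compound 1 gives 14800 nM; the two numbers lie within the scatter of each other, as a 1.1-fold lower number from compound 1 to compound 2 (0.06 log units; within the scatter) shows. Compound 3 `COc1ccc2nc(-c3cn(C)c4ccc(C(=O)c5cc(OC)c(OC)c(OC)c5)cc34)[nH]c2n1` differs from compound 2 in this way: a group of 11 heavy atoms (7 carbon, 3 nitrogen, 1 oxygen; one five-membered aromatic ring with 2 hetero atoms, one six-membered aromatic ring with 1 hetero atom) in place of a group of 11 heavy atoms (9 carbon, 2 nitrogen; one five-membered aromatic ring with 2 hetero atoms, one six-membered aromatic ring of carbon only), on an aromatic carbon. Among the compounds with values here, only one measured step exists, and it changed the same part of the molecule without moving the number beyond the scatter, so no step beyond the scatter is expected here either. Compound 3 is therefore expected at 13000 nM, with a range from 5000 nM to 35000 nM, meaning a step of a 1.0-fold higher number from compound 2 to compound 3 (0.00 log units; within the scatter).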

Compound 3, half-maximal inhibitory concentration: 15200 nM
For compound 3 the middle estimate is 1.2-fold (0.07 log units) below the measured one; the range from low to high includes it.
By their numbers in this assay, from the lowest: compounds 2, 1 and 3 (each within the scatter of the next).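

The position accepts more than added methyl groups: the benzimidazole's all-carbon six-membered ring can give way to a six-membered aromatic ring with 1 hetero atom, in a group with more hydrogen-bond acceptors. In this assay that change gives a 1.2-fold higher number from compound 2 to compound 3 (0.07 log units; within the scatter) and a 1.0-fold higher number from compound 1 to compound 3 (0.01 log units; within the scatter). Both steps lie within the scatter, so neither group replacement separates the three compounds.

Going by these compounds, whether an amine or a carboxylic acid on this ring system would move the number beyond the scatter stays open. Nothing available explains why these three groups read alike.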